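Swapping the aryl amine in a quinazoline cytotoxicity series

The source may report more compounds than this note shows. Statements on the series, on what has been measured and on what is new or still open speak of the compounds shown alone.

Measured so far:
compound 1 `CCS(=O)(=O)Nc1cc(-c2ccc3ncnc(Nc4ccc(OC(F)(F)F)cc4)c3c2)cnc1OC` 23700 nM
compound 2 `CCCCS(=O)(=O)Nc1cc(-c2ccc3ncnc(Nc4ccc(F)c(Cl)c4)c3c2)cnc1OC` 65800 nM
compound 3 `COC(=O)c1cccc(Nc2ncnc3ccc(-c4cnc(OC)c(NS(=O)(=O)c5ccc(F)cc5F)c4)cc23)c1` 22400 nM

In a functional assay on MCF7 cells (Homo sapiens) for cytotoxicity, read by sulforhodamine B assay, with a stated time of 72 h (on this read-out lower numbers stand for stronger inhibition and higher numbers for weaker inhibition), compound 1 gives 23700 nM, the second highest of the three numbers. Compound 3 sits within the scatter of it, so the two cannot be told apart, while compound 2 lies beyond the scatter with a higher number. Compound 4 `CCS(=O)(=O)Nc1cc(-c2ccc3ncnc(Nc4ccc(OC)nc4)c3c2)cnc1OC` has not yet been measured. It differs from compound 1 in one place: 6-methoxypyridin-3-yl in place of 4-(trifluoromethoxy)phenyl on a nitrogen on an aromatic ring. Within the data shown here, no measured pair shows this change, so its effect is unknown. The step of a 1.3-fold higher number from compound 1 to compound 4 (0.10 log units; within the scatter) is expected to be small, with no direction beyond the scatter. Compound 4 is therefore expected to give about 30000 nM, somewhere between 8000 nM and 100000 nM.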

Compound 4, half-maximal inhibitory concentration: 3770 nM
Estimate against measurement, compound 4: 8.0-fold (0.90 log units) above, outside the stated range (below it).
By their numbers in this assay, from the lowest: compound 4; then compounds 3 and 1 (each within the scatter of the next); then compound 2.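

In this assay the group on a nitrogen on an aromatic ring proves able to shift the number: 6-methoxypyridin-3-yl in place of 4-(trifluoromethoxy)phenyl gives a 6.3-fold lower number from compound 1 to compound 4 (0.80 log units; beyond the scatter) and lies beyond the scatter. The earlier compounds shown here differ in more than one place, so they could not isolate this position. Nothing at hand explains the step. From the compounds shown here alone, the change alters the ring and its substituent together, so their separate shares stay open. A 4-methoxyphenyl group on the same nitrogen would separate them.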